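The source may hold more compounds than are shown below. What is called first, only, known or untested is meant among the compounds shown, and "the series" means these compounds.

Three related compounds were examined in a functional assay on VCaP cells (Homo sapiens) for antiproliferative activity, read by CCK-8 assay, with a stated time of 6 days; a higher number here means a weaker inhibitor, a lower number a stronger inhibitor. For compound 1 (`N#Cc1ccc(N2CCc3cc(-c4cnc5ccccc5c4)ccc32)cc1C(F)(F)F`) the entry reads "not determined" (no result reported). Compound 2 (`Cc1noc(C)c1-c1cccc2c1CCCN2c1ccc(C#N)c(C(F)(F)F)c1`) reached only a limit of the assay, > 30000 nM. Compound 3 (`N#Cc1ccc(N2CCc3cc(-c4cnc5ccccc5c4)ccc3C2)cc1C(F)(F)F`) likewise gave only a limit, > 30000 nM. Compound 3 therefore stands at the limit of > 30000 nM in this assay, at which 2 of the 3 values shown sit, and no actual potency can be read for it.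

Compound 4 (`N#Cc1ccc(N2CCc3cc(-c4ccncc4)ccc3C2)cc1C(F)(F)F`) keeps the core of compound 3 but has pyridin-4-yl in place of quinolin-3-yl on an aromatic carbon. Within the data shown here, no measured pair shows what a change of this kind does in this assay. A step beyond the usual scatter is therefore not expected in either direction, and the result may well be another limit. The expected step is a number no higher from compound 3 to compound 4 (the limit leaves the size open). This expectation rests on compound 3, which gave > 30000 nM. For compound 4 the estimated value is 30000 nM, within an estimated range from 10000 nM to 50000 nM.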

Compound 4, half-maximal inhibitory concentration: 3500 nM
Estimate against measurement, compound 4: 8.6-fold (0.93 log units) above; the measured number lies below the stated range.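

In this assay, pyridin-4-yl in place of quinolin-3-yl on this aromatic carbon gives an at least 8.5-fold lower number from compound 3 to compound 4 (0.93 log units; beyond the scatter). The position therefore does respond to the group it carries, and the single six-membered aromatic ring that enters reads better here than the two fused rings that leave. Compound 4 is also the only compound shown with an actual potency, and the step starts from a limit, so its full size stays open: the limit of > 30000 nM in this assay, at which 2 of the 4 values shown sit.

The compounds shown leave open whether the ring nitrogen of pyridin-4-yl matters or whether removing the fused carbon ring is enough, a question that a plain phenyl group at this position would address. From the compounds shown here alone, how pyridin-3-yl, or a pyridine bearing an amine or a carboxylic acid, would read in this assay also remains unknown.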